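Amide-nitrogen aryl exchange in a thiazolidinedione series

The source may report more compounds than this note shows. Statements on the series, on what has been measured and on what is new or still open speak of the compounds shown alone.

Measured compounds:
compound 1 `O=C(COc1ccc2cc(/C=C3/SC(=O)NC3=O)ccc2c1)Nc1cccc(F)n1` — 7200 nM
compound 2 `COc1ccc(NC(=O)COc2ccc3cc(/C=C4/SC(=O)NC4=O)ccc3c2)cc1` — > 50000 nM (limit)

Compound 2 stands at the weak end of what has been measured. In an assay on isolated protein for inhibition of histone deacetylase 8 (Homo sapiens), with a stated time of 1 h (on this read-out higher numbers stand for weaker inhibition and lower numbers for stronger inhibition), compound 2 gives only a limit of the assay, > 50000 nM, and no number; it sits at the limit of > 50000 nM in this assay, at which 1 of the 2 values shown sits. Compound 1, in this assay, gives 7200 nM. Among the compounds with values here, the single measured step is an at least 6.9-fold higher number from compound 1 to compound 2 (0.84 log units; beyond the scatter), which replaced the 6-fluoropyridin-2-yl with 4-methoxyphenyl on the amide-type nitrogen.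

Compound 3 `O=C(COc1ccc2cc(/C=C3/SC(=O)NC3=O)ccc2c1)Nc1cc(Cl)cc(C(F)(F)F)c1` differs from compound 2 by 3-chloro-5-(trifluoromethyl)phenyl in place of 4-methoxyphenyl on an amide-type nitrogen. Within the data shown here, the change is again an exchange of the aryl group on the amide-type nitrogen whose other neighbour is the carbonyl carbon, so the one measured step bears on it directly: an exchange at this place moved the number by an at least 6.9-fold higher number from compound 1 to compound 2 (0.84 log units; beyond the scatter). A move of a similar size is plausible here, in either direction, but with compound 2 at a limit only a decrease would be registered as a number.

Compound 3 is expected to come in around 20000 nM, within 3000 nM to 100000 nM. This estimate means a step of an at least 2.5-fold lower number from compound 2 to compound 3 (0.39 log units; beyond the scatter), with a fair chance that compound 3 again returns only a limit.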

Compound 3, half-maximal inhibitory concentration: > 50000 nM
Compound 3 was reported as a limit; the forecaster's own chance of this, stated with the estimate: 45%; middle value at least 2.5-fold (0.39 log units) away from the limit.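

Exchanging 6-fluoropyridin-2-yl for 3-chloro-5-(trifluoromethyl)phenyl on the amide-type nitrogen gives an at least 6.9-fold higher number from compound 1 to compound 3 (0.84 log units; beyond the scatter) in this assay. A second phenyl group at this place, with chlorine and trifluoromethyl in place of methoxy and more heavy atoms, therefore also fails to give a number, and among the three compounds shown only compound 1, with the one aryl group that is not a phenyl, gives one. The step from compound 2 to compound 3 cannot be read because both compounds stand at a limit of the assay, so the two phenyl groups cannot be ranked against each other: the limit of > 50000 nM in this assay, at which 2 of the 3 values shown sit.

Still open, on these data alone, is how far compound 2 and compound 3 lie beyond that limit, and whether the number of compound 1 goes with the ring nitrogen of 6-fluoropyridin-2-yl, with its fluorine, or with the two together. Also open, as far as these compounds go, is how an unsubstituted pyridin-2-yl, or a pyridine ring carrying an amine or a carboxylic acid, would read on the same amide-type nitrogen.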